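The source may hold more compounds than are shown below. What is called first, only, known or untested is meant among the compounds shown, and "the series" means these compounds.

Working notes on the series. Within the data shown here, in a functional assay on A549 cells (Homo sapiens) for cytotoxicity, read by MTT assay, with a stated time of 72 h (on this read-out lower numbers stand for stronger inhibition and higher numbers for weaker inhibition), compound 1 (`COc1ccc(OC)c(/C=C/C(=O)Nc2cc3c(Nc4ccc(F)c(Cl)c4)ncnc3cc2O[C@H]2CCOC2)c1`) gives 7300 nM and compound 2 (`O=C(/C=C/c1cc(Br)c(O)c(Br)c1)Nc1cc2c(Nc3ccc(F)c(Cl)c3)ncnc2cc1O[C@H]1CCOC1`) gives 28800 nM as the higher of the only two numbers so far, which makes compound 2 the weaker of the pair.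

Compound 3 (`COc1ccc(/C=C/C(=O)Nc2cc3c(Nc4ccc(F)c(Cl)c4)ncnc3cc2O[C@H]2CCOC2)c(OC)c1OC`) has not yet been measured. It differs from compound 2 on a double-bonded chain carbon bound to a double-bonded chain carbon (2,3,4-trimethoxyphenyl in place of 3,5-dibromo-4-hydroxyphenyl on a double-bonded chain carbon bound to a double-bonded chain carbon) with 2,3,4-trimethoxyphenyl in place of 3,5-dibromo-4-hydroxyphenyl.

Among the measured compounds shown here, one measured step bears on this change: a 3.9-fold higher number from compound 1 to compound 2 (0.60 log units; beyond the scatter) is a modest step at the same place and also separates a methoxy-bearing ring from the 3,5-dibromo-4-hydroxyphenyl group. Compound 3 also carries methoxy groups and no bromine, so a change of similar size in the opposite direction is expected, towards compound 1 at 7300 nM as its reference. A single step is thin support, so the range stays wide.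

The expected step is a 3.2-fold lower number from compound 2 to compound 3 (0.51 log units; beyond the scatter) in this assay as an estimate towards a lower number. Compound 3 is estimated at 9000 nM with an expected range from 3500 nM to 23000 nM as its limits of expectation.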

Compound 3, half-maximal inhibitory concentration: 70 nM
Estimate against measurement, compound 3: 130-fold (2.11 log units) above, and the stated range ends above it.
By their numbers in this assay, from the lowest: compound 3; then compound 1; then compound 2.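

Working notes, continued. In this assay, the group on a double-bonded chain carbon bound to a double-bonded chain carbon carries far more of the range than the first pair showed: a 410-fold lower number from compound 2 to compound 3 (2.61 log units; beyond the scatter) is a large step, whereas a 3.9-fold higher number from compound 1 to compound 2 (0.60 log units; beyond the scatter) is only modest. The step of a 100-fold lower number from compound 1 to compound 3 (2.02 log units; beyond the scatter) is also large, so carrying methoxy groups and no bromine does not by itself set the number, since 2,5-dimethoxyphenyl and 2,3,4-trimethoxyphenyl both fit that description and still lie far apart. Nothing measured on these compounds gives a reason for this gap.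

The compounds shown cannot separate the count of methoxy groups from their arrangement on the ring, as 2,5-dimethoxyphenyl and 2,3,4-trimethoxyphenyl differ in both. They also leave open whether the low number of compound 3 survives when one of its methoxy groups gives way to a hydroxyl, an amine or a carboxylic acid at this same place on the shared core.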